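A Methoxyphenyl in Place of a Vinyl Group

The compounds below may be only part of what the source reports. "The series", "measured", "known", "first", "only" and "open" are said of these compounds alone.

For the measured compounds named here, compound 1 `C=CCSc1nc2c(c(=O)[nH]c(=O)n2C)n1CCC` was tested in a functional assay on MGC-803 cells (Homo sapiens) for inhibition, read by MTT assay, with a stated time of 48 h, tested at 20 uM (a higher number here means more inhibition at the concentration tested (going by the name of the read-out), a lower number less inhibition), and gives 5.5%, the lower of only two numbers so far, with the gap to its neighbour lying within the scatter. Compound 2 `CCCn1c(SCc2ccc(C(C)(C)C)cc2)nc2c1c(=O)[nH]c(=O)n2C` gives 10.3% in this assay. Compound 3 `CCCn1c(SCc2cccc(OC)c2)nc2c1c(=O)[nH]c(=O)n2C` has not yet been measured; it differs from compound 1 in one place: 3-methoxyphenyl in place of vinyl on a saturated chain carbon bound to a sulfur. Going by the values given here, no measured step of this kind exists to lean on, so only a small rise, hardly beyond the scatter, is expected, and the step from compound 1 to compound 3 is estimated as a number 4.5 percentage points higher from compound 1 to compound 3 (within the scatter). Compound 3 is therefore expected to give 10%, within 0% to 25%.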

Compound 3, a percentage reported as inhibition, at one concentration (the size of the read-out at that concentration, not a potency): 34.2%
Beside the measured number, compound 3's estimate is 24.2 percentage points below it; measured number above the stated range.
By their numbers in this assay, from the lowest: compounds 1 and 2 (each within the scatter of the next); then compound 3.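

In this assay, for the compounds shown here, 3-methoxyphenyl in place of vinyl on a saturated chain carbon bound to a sulfur gives a number 28.7 percentage points higher from compound 1 to compound 3 (beyond the scatter), the first step at this place to be read, and it lies beyond the scatter. The group held here can therefore change the inhibition seen at the concentration tested. Nothing measured here says why the number changes.

The compounds shown leave open whether the methoxy group or the phenyl ring accounts for the step. Plain phenyl or 4-methoxyphenyl at this place would help to separate the two.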